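Furan-2-yl for 4-Fluorophenyl on a Shared Thiazolidinedione Core

The source may report more compounds than this note shows. Statements on the series, on what has been measured and on what is new or still open speak of the compounds shown alone.

Measured so far:
compound 1 `O=C(O)c1ccc(CN2C(=O)S/C(=C\c3ccc(F)cc3)C2=O)cc1` 32000 nM
compound 2 `O=C(O)c1ccc(CN2C(=O)S/C(=C\c3ccccn3)C2=O)cc1` 78000 nM

The two measured compounds share a core and differ only in the group on a double-bonded chain carbon bound to a double-bonded ring carbon. In a functional assay on HT-29 cells (Homo sapiens) for cytotoxicity, read by MTT assay, with a stated time of 24 h (a higher number here means a weaker inhibitor, a lower number a stronger inhibitor), compound 1 gives 32000 nM, the lowest of the two numbers; the nearest is compound 2 at 78000 nM. For the measured compounds named here, the one measured step, a 2.4-fold higher number from compound 1 to compound 2 (0.39 log units; beyond the scatter), shows that replacing the 4-fluorophenyl with a six-membered aromatic ring carrying one hetero atom weakens inhibition modestly but beyond the scatter.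

Compound 3 `O=C(O)c1ccc(CN2C(=O)S/C(=C\c3ccco3)C2=O)cc1` has not yet been measured. It differs from compound 1 by furan-2-yl in place of 4-fluorophenyl on a double-bonded chain carbon bound to a double-bonded ring carbon. Here a five-membered aromatic ring with one hetero atom enters where the 4-fluorophenyl leaves. The step from compound 1 to compound 2 bears on this change, since in both a hetero-atom ring replaces the same 4-fluorophenyl, and it was a modest weakening. A modest rise in the number, of about the same size, is therefore expected, a 1.7-fold higher number from compound 1 to compound 3 (0.24 log units; within the scatter). Compound 3 is expected to give about 55000 nM in this assay, within a range from 22000 nM to 130000 nM.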

Compound 3, half-maximal inhibitory concentration: 94000 nM
The estimate for compound 3 lay 1.7-fold (0.23 log units) below the measured number; measured number inside the range.
By their numbers in this assay, from the lowest: compound 1; then compounds 2 and 3 (each within the scatter of the next).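

In this assay, the step to furan-2-yl, a 2.9-fold higher number from compound 1 to compound 3 (0.47 log units; beyond the scatter), is a second case beyond the scatter, so among the compounds shown, both hetero-atom rings on the double-bonded chain carbon give a higher number than the 4-fluorophenyl of compound 1. The earlier pair could not show whether this held only for pyridin-2-yl, but compounds 2 and 3 now show that it is not confined to that ring. The two hetero-atom rings also cannot be separated, a 1.2-fold higher number from compound 2 to compound 3 (0.08 log units; within the scatter), so the change from a six-membered to a five-membered hetero-atom ring has no readable effect on the number in this assay, and nothing given here accounts for the shift away from 4-fluorophenyl.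

The compounds shown leave open whether the lower number of compound 1 goes with its fluorine or with its ring of carbon only, a question that a plain phenyl at this place would address. They also leave open whether a thiophen-2-yl would read with furan-2-yl, and how an amine or a methoxy group on the ring would read.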